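Removing the Methoxymethyl Group: From Compound 3 to Compound 4

The source may report more compounds than this note shows. Statements on the series, on what has been measured and on what is new or still open speak of the compounds shown alone.

Three compounds of a shared core have been examined in an ADME assay on HT-29 cells (Homo sapiens) for cytotoxicity, read by MTT assay, with a stated time of 72 h; a higher number here means a weaker inhibitor, a lower number a stronger inhibitor. Compound 1 `COc1ccc(C2=C(c3cc(OC)c(OC)c(OC)c3)C(=O)C(OC(C)=O)C2)cc1Cl` gives < 1 ug/mL, which is a limit of the assay rather than a number. Compound 2 `COc1ccc(C2=C(c3cc(OC)c(OC)c(OC)c3)C(=O)C(O[SiH2]C(C)(C)C)C2)cc1OC(C)C` gives 9 ug/mL. Compound 3 `COCOc1cc(C2=C(c3cc(OC)c(OC)c(OC)c3)C(=O)CC2O[SiH2]C(C)(C)C)ccc1OC` gives 43 ug/mL, the higher of the two numbers, and its gap to compound 2 lies beyond the usual scatter.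

Compound 4 `COc1ccc(C2=C(c3cc(OC)c(OC)c(OC)c3)C(=O)CC2O[SiH2]C(C)(C)C)cc1O` has not yet been measured in this assay. It differs from compound 3 in one place: hydrogen in place of methoxymethyl on an oxygen on an aromatic ring. No measured pair among these compounds shows this change, so the direction rests on expectation alone. Compound 4 is expected to give a lower number than compound 3, a step of a 4.3-fold lower number from compound 3 to compound 4 (0.63 log units; beyond the scatter). Compound 4 is estimated at 10 ug/mL, with a range from 2 ug/mL to 40 ug/mL.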

Compound 4, half-maximal inhibitory concentration: 38 ug/mL
Beside the measured number, compound 4's estimate is 3.8-fold (0.58 log units) below it; low and high end bracket the measured number.
By their numbers in this assay, from the lowest: compound 2; then compounds 4 and 3 (each within the scatter of the next). At a limit, below all of these: compound 1.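

Among the compounds shown here, the step in this assay, a 1.1-fold lower number from compound 3 to compound 4 (0.05 log units; within the scatter), is the first measured pair at this position, and it shows that exchanging methoxymethyl for hydrogen on this oxygen leaves the number within the scatter. Methoxymethoxy and hydroxy therefore cannot be told apart here. Nothing measured here accounts for this result. What the compounds shown leave open is whether an amine in place of the hydroxy, or a longer chain on this oxygen, would move the number beyond the scatter.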